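Losing the 3-methylbut-2-en-1-yl chain from compound 1

The compounds below may be only part of what the source reports. "The series", "measured", "known", "first", "only" and "open" are said of these compounds alone.

Among the compounds with values here, in a functional assay on HepG2 cells (Homo sapiens) for inhibition, read by MTT assay, with a stated time of 72 h (a higher number here means a weaker inhibitor, a lower number a stronger inhibitor), compound 1 (`COc1ccc(/C=C/C(=O)c2c(OC)cc(O)c(CC=C(C)C)c2O)cc1`) gives 32400 nM and stands highest of the two numbers so far, while compound 2 (`COc1ccccc1/C=C/C(=O)c1c(OC)cc(O)c(CC=C(C)C)c1O`) gives 14600 nM as its value. Compound 3 (`COc1ccc(/C=C/C(=O)c2c(O)cc(O)cc2OC)cc1`) carries hydrogen in place of 3-methylbut-2-en-1-yl on an aromatic carbon, ortho to two hydroxy groups (hydrogen in place of 3-methylbut-2-en-1-yl on an aromatic carbon). Within the data shown here, the one measured step (a 2.2-fold lower number from compound 1 to compound 2 (0.35 log units; beyond the scatter)) is modest and swaps 4-methoxyphenyl for 2-methoxyphenyl, leaving this chain untouched, so no measurement tests the change directly. A similarly small move toward a higher number is expected, with the estimated step (a 1.4-fold higher number from compound 1 to compound 3 (0.14 log units; within the scatter)) staying modest. For compound 3 the estimated value is 45000 nM with an expected range from 16000 nM to 120000 nM as its likely span.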

Compound 3, half-maximal inhibitory concentration: 18100 nM
Estimate against measurement, compound 3: 2.5-fold (0.40 log units) above; the range from low to high includes it.
By their numbers in this assay, from the lowest: compounds 2, 3 and 1 (each within the scatter of the next, the first and the last beyond it).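

The first direct test of this position gives a 1.8-fold lower number from compound 1 to compound 3 (0.25 log units; within the scatter) in this assay, so replacing the 3-methylbut-2-en-1-yl chain with hydrogen produces no change that stands clear of the scatter. On this core, therefore, the chain's five carbons and its double bond are not shown to matter for the read-out. Nothing measured here bears on why this is so.

Going by these compounds, whether a longer chain or a carboxylic acid on this aromatic carbon would shift the number remains open. It is also unknown whether losing the chain would read the same with the 2-methoxyphenyl of compound 2.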